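The source may hold more compounds than are shown below. What is called first, only, known or untested is meant among the compounds shown, and "the series" means these compounds.

Three close analogues share one core and have been measured in a functional assay for inhibition, with Rattus norvegicus as the target; a lower number here means a stronger inhibitor, a higher number a weaker inhibitor. Compound 1 `CNc1nc(Cl)nc2c1ncn2[C@H]1CC(OP(=O)(O)O)[C@]2(CO)CC12` gives 29000 nM in this assay. Compound 3 `CNc1nc(Cl)nc2c1ncn2[C@H]1CC(OP(=O)(O)O)[C@]2(COC(C)=O)CC12` gives 16000 nM in the same assay. The two differ by one change, (hydrogen in place of acetyl on an oxygen on a saturated carbon), and the step of a 1.8-fold higher number from compound 3 to compound 1 (0.26 log units; within the scatter) is small. Compound 2 `CNc1nc(Cl)nc2c1ncn2[C@H]1CC(OC(C)=O)[C@]2(COP(=O)(O)O)CC12` gives 10000 nM in this assay, the lowest of the three numbers; how its core differs from that of compound 3 is not broken down here, and the gap to compound 3 lies within the scatter, while the gap to compound 1 lies beyond it.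

Compound 4 `CNc1nc(Cl)nc2c1ncn2[C@H]1CC(O)[C@]2(COP(=O)(O)O)CC12` has not yet been measured. It differs from compound 2 by hydrogen in place of acetyl on an oxygen on a saturated carbon. This is the same kind of change as that from compound 3 to compound 1, not the same: there the oxygen sits on a saturated carbon whose other neighbour is a saturated chain carbon, here on one whose other neighbour is a saturated ring carbon. Because the earlier step of a 1.8-fold higher number from compound 3 to compound 1 (0.26 log units; within the scatter) was small, a step of similar size, a 1.5-fold higher number from compound 2 to compound 4 (0.18 log units; within the scatter), is expected from compound 2 to compound 4. Compound 4 is therefore estimated at 15000 nM in this assay, with a likely range from 6000 nM to 40000 nM.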

Compound 4, inhibition constant: 33000 nM
Beside the measured number, compound 4's estimate is 2.2-fold (0.34 log units) below it; low and high end bracket the measured number.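

In this assay, going from acetoxy to hydroxy gives a 3.3-fold higher number from compound 2 to compound 4 (0.52 log units; beyond the scatter), a step that is modest but clears the scatter, which the same change on the other core does not. Even so, the two steps cannot be told apart when set side by side: the same change on two cores in this assay, a 1.8-fold higher number (0.26 log units; within the scatter) from compound 3 to compound 1 and a 3.3-fold higher number (0.52 log units; beyond the scatter) from compound 2 to compound 4, 1.8-fold (0.26 log units) apart, within the scatter of two such steps. The change therefore carries over between these two cores as far as this comparison can resolve, but two pairs are a thin base, and they show neither that its size would hold on other cores of the series nor what lies behind it.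

What the compounds shown leave open is whether a longer acyl chain such as butyryl, or a methyl ether, on that oxygen would behave like the acetyl or like the hydroxy. Equally open, from the compounds shown here alone, is what happens to the number in this assay when the phosphate gives way to a carboxylic acid.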